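The source may report more compounds than this note shows. Statements on the series, on what has been measured and on what is new or still open speak of the compounds shown alone.

Measured in a functional assay on MOLT-4 cells (Homo sapiens) for antiproliferative activity, read by MTT assay, with a stated time of 48 h; on this read-out higher numbers stand for weaker inhibition and lower numbers for stronger inhibition:
- compound 1 `Clc1ccc(Nc2nc(Nc3cn[nH]c3)ncc2Cl)cc1`: 1370 nM
- compound 2 `Clc1cnc(Nc2cn[nH]c2)nc1Nc1ccccc1`: > 5000 nM

Compound 2 stands at > 5000 nM, which is a limit and not a number.

Compound 3 `Fc1ccc(Nc2nc(Nc3cn[nH]c3)ncc2Cl)cc1` carries fluoro in place of hydrogen on an aromatic carbon of compound 2, para to a large group: fluoro in place of hydrogen on an aromatic carbon. Among the measured compounds shown here, one measured step bears on this change, an at least 3.6-fold higher number from compound 1 to compound 2 (0.56 log units; beyond the scatter), which removes chloro from a ring of the same kind and lies beyond the scatter. Read backwards, that step suggests that a halogen on this carbon may lower the number, although it is a single pair and fluoro itself is untested. For the measured compounds named here, a step downward in this assay is therefore expected, probably no larger than the one seen with compound 1 at 1370 nM. Compound 3 is expected at 2500 nM, with an estimated range of 1000 nM to 6000 nM. The expected change is an at least 2.0-fold lower number from compound 2 to compound 3 (0.30 log units; that floor lies within the scatter).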

Compound 3, half-maximal inhibitory concentration: 3280 nM
Compound 3: the middle estimate sits 1.3-fold (0.12 log units) below what was measured; measured number inside the range.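

In this assay, the identity of the halogen on the aromatic carbon para to a large group now matters, with chloro giving the lower number: the change from chloro to fluoro is a 2.4-fold higher number from compound 1 to compound 3 (0.38 log units; beyond the scatter). Fluoro in place of hydrogen gives an at least 1.5-fold lower number from compound 2 to compound 3 (0.18 log units; that floor lies within the scatter), so this pair does not establish a gain from fluoro over hydrogen. Compound 2 has only a limit, which leaves this step as a floor and not a measured size: the limit of > 5000 nM in this assay, at which 1 of the 3 values shown sits.

From the compounds shown here alone, whether bromo, methyl or methoxy on this carbon would give a number nearer to that of chloro or of fluoro remains open. Among the compounds shown here, also open is how an amine or a carboxylic acid would behave here, as the series so far shows only hydrogen, fluoro and chloro at this position.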